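The source may report more compounds than this note shows. Statements on the series, on what has been measured and on what is new or still open speak of the compounds shown alone.

Among the measured compounds shown here, in an ADME assay on HepG2 cells (Homo sapiens) for cytotoxicity, read by luminescence, CellTiter-Glo and ATP content, with a stated time of 72 h (on this read-out higher numbers stand for an effect only at larger amounts of compound and lower numbers for an effect already at smaller amounts), compound 3 `COc1ccc(F)cc1CNCCCNc1ccnc2cc(-c3ccc(C(C)(C)C)cc3)ccc12` gives 620 nM, the lowest of the three numbers measured so far. Compound 1 `COc1cccc(Oc2ccc3c(NCCCNCc4cc(F)ccc4OC)ccnc3c2)c1` gives 7100 nM and compound 2 `COc1ccc(F)cc1CNCCCNc1ccnc2cc(Oc3ccc(Cl)cc3)ccc12` gives 4500 nM; the step of a 1.6-fold lower number from compound 1 to compound 2 (0.20 log units; within the scatter) lies within the scatter, whereas the steps of an 11-fold lower number from compound 1 to compound 3 (1.06 log units; beyond the scatter) and a 7.3-fold lower number from compound 2 to compound 3 (0.86 log units; beyond the scatter) are both beyond it, so compound 3 stands clearly apart.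

Compound 4 `COc1ccc(F)cc1CNCCCNc1ccnc2cc(-c3cccc4ccccc34)ccc12` differs from compound 3 in one place: naphthalen-1-yl in place of 4-(tert-butyl)phenyl on an aromatic carbon. Both measured steps that bear on this position, from compound 1 and from compound 2 to compound 3, exchanged a group held through an oxygen for a group attached directly to the aromatic carbon, and both lowered the number. The change to compound 4 keeps a directly attached group and only swaps one such group for another; no measured step of this kind exists among these compounds. The expected step of a 1.1-fold higher number from compound 3 to compound 4 (0.05 log units; within the scatter) is therefore none beyond the scatter. Compound 4 is estimated at 700 nM, with a range from 250 nM to 2000 nM in this assay.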

Compound 4, half-maximal effective concentration: 16000 nM
Beside the measured number, compound 4's estimate is 23-fold (1.36 log units) below it, outside the stated range (above it).
By their numbers in this assay, from the lowest: compound 3; then compounds 2 and 1 (each within the scatter of the next); then compound 4.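

In this assay direct attachment at this position does not by itself bring the number down: naphthalen-1-yl in place of 4-(tert-butyl)phenyl gives a 26-fold higher number from compound 3 to compound 4 (1.41 log units; beyond the scatter) even though both groups are built only of carbon and have the same heavy-atom count. Both a 3.6-fold higher number from compound 2 to compound 4 (0.55 log units; beyond the scatter) and a 2.3-fold higher number from compound 1 to compound 4 (0.35 log units; beyond the scatter) place compound 4 highest of the four, so a directly attached group can fall on either side of the groups held through an oxygen. No measurement at hand accounts for this gap between the two directly attached groups.

The compounds shown leave open whether naphthalen-2-yl, or a phenyl ring carrying an amine or a carboxylic acid, would land nearer compound 3 or compound 4. They also leave open whether so large a step would persist with a longer chain joining the shared core to its amine.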